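Extending an amide chain and cell toxicity

The source may report more compounds than this note shows. Statements on the series, on what has been measured and on what is new or still open speak of the compounds shown alone.

The measured compounds, each in an ADME assay on MDBK cells (Bos taurus) for cytotoxicity, read by MTT assay, with a stated time of 96 h; on this read-out higher numbers stand for lower toxicity in this test and lower numbers for higher toxicity in this test:
Compound 1, `CCC(=O)Nc1ccc(-c2nc3cc(C(F)(F)F)ccc3n2C2CCCCC2)cc1`, gives 18000 nM in this assay.
Compound 3, `CC(=O)Nc1ccc(-c2nc3cc(C(F)(F)F)ccc3n2C2CCCCC2)cc1`, gives 17000 nM in this assay.
Compound 2, `CC(=O)Nc1ccc(-c2nc3ccccc3[nH]2)cc1`, reaches only a limit of this test, > 100000 nM in this assay.

Compound 3 and compound 1 share one core and differ in a single spot: methyl in place of hydrogen on a saturated chain carbon bound to a carbonyl carbon. The step this made is a 1.1-fold higher number from compound 3 to compound 1 (0.02 log units; within the scatter), so the two values are read as the same within this test. Compound 2 carries a different core; how the two cores differ is not broken down here.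

Compound 4, `CCC(=O)Nc1ccc(-c2nc3ccccc3[nH]2)cc1`, has not yet been measured. It stands to compound 2 as compound 1 stands to compound 3: the change is methyl in place of hydrogen on a saturated chain carbon bound to a carbonyl carbon, at the same place. Since this change left the measured pair within the usual scatter, the step from compound 2 to compound 4 is expected to be of the same kind and size, namely a number no higher from compound 2 to compound 4 (the limit leaves the size open), because the measured version of it gave a 1.1-fold higher number from compound 3 to compound 1 (0.02 log units; within the scatter). Compound 2 itself gave no number, only (the limit of > 100000 nM in this assay, at which 1 of the 3 values shown sits), so compound 4 is expected to end at that limit as well or close to it. The estimate for compound 4 in this assay is 100000 nM, with a plausible range from 50000 nM to 200000 nM.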

Compound 4, half-maximal cytotoxic concentration: > 100000 nM
Compound 4: no number, only a limit (the forecaster's own chance of this, stated with the estimate: 80%); the middle value sits exactly at the limit.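

No step can be read from compound 2 to compound 4, since each gives only a limit in this assay and not a number: the limit of > 100000 nM in this assay, at which 2 of the 4 values shown sit.

The compounds shown leave open where the true values of compound 2 and compound 4 lie beyond that limit, and so whether going from acetamido to propanoylamino makes any difference on their shared core.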